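The source may report more compounds than this note shows. Statements on the series, on what has been measured and on what is new or still open speak of the compounds shown alone.

Measured so far:
compound 1 `C=C(C)c1ccc(N2CCN(C(=O)c3oc(C)nc3-c3ccccc3)CC2)cc1`: "not active" (no number reported)
compound 2 `Cc1nc(-c2ccccc2)c(C(=O)N2CCN(c3ccc(C(F)(F)F)cc3)CC2)o1`: > 1000 nM
compound 3 `Cc1nc(-c2ccccc2)c(C(=O)N2CCN(c3ccc(F)cc3)CC2)o1`: > 1000 nM

These values come from a functional assay on HL-60 cells (Homo sapiens) for inhibition, read by MTT assay, with a stated time of 72 h; a higher number here means a weaker inhibitor, a lower number a stronger inhibitor. The entries for compound 2 and compound 3 are limits and not numbers, and compound 1 has no number at all. The series therefore shows no measured potency, and the limit of > 1000 nM in this assay, at which 2 of the 3 values shown sit, is all that can be said of its position. Within the data shown here, the only measured step is a step that the two limits leave unreadable from compound 2 to compound 3, which gives no size to carry forward.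

Compound 4 `Cc1nc(-c2ccccc2)c(C(=O)N2CCN(c3ccccc3F)CC2)o1` is the next entry, with 2-fluorophenyl in place of 4-fluorophenyl on an amine nitrogen in a ring. Among the measured compounds shown here, no measured step covers a move of the fluorine, so no direction can be argued. The expectation rests on compound 3, whose entry of > 1000 nM is a limit. The expected change in this assay is a step that the limit leaves unreadable from compound 3 to compound 4, with no real shift anticipated. Compound 4 is estimated at 2000 nM, with an expected range of 400 nM to 10000 nM, and a further report as a limit is the likeliest outcome.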

Compound 4, half-maximal inhibitory concentration: 147 nM
Estimate against measurement, compound 4: 14-fold (1.13 log units) above, and the stated range ends above it.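

In this assay, the group on the amine nitrogen in a ring can separate compounds in this series: 2-fluorophenyl in place of 4-fluorophenyl, with the same atoms joined differently, gives an at least 6.8-fold lower number from compound 3 to compound 4 (0.83 log units; beyond the scatter). Putting 2-fluorophenyl in place of 4-(trifluoromethyl)phenyl gives an at least 6.8-fold lower number from compound 2 to compound 4 (0.83 log units; beyond the scatter), so both readable steps point the same way. The place of the fluorine on the phenyl ring thus matters in this assay, which the earlier entries could not show, as they offered only limits: the limit of > 1000 nM in this assay, at which 2 of the 4 values shown sit.

On these data alone, the full size of both steps stays open, since each is measured from a limit and not from a number. The compounds shown also do not tell whether a chlorine or a methoxy group in place of the fluorine of compound 4 would keep the result.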